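A few compounds are considered here, and "the series" means these few. Any claim that something is new, unique, unknown or untested is made for them only; others in the source may bear on it.

Among the compounds with values here, in a functional assay on the whole organism (strain Swiss Albino) with Mus musculus as the target (on this read-out lower numbers stand for an effect already at smaller amounts and higher numbers for an effect only at larger amounts of compound), compound 2 `Cc1cc(Cl)ccc1NC(=O)[C@@H](C)N` gives 39.2 mg/kg, the lower of the two numbers seen, and its only neighbour is compound 1 `Cc1cc(Cl)ccc1NC(=O)[C@H](C)N`, which in this assay gives 41.3 mg/kg. Within the data shown here, the single step seen so far, a 1.1-fold lower number from compound 1 to compound 2 (0.02 log units; within the scatter), rests on (the fact that compounds 1 and 2 differ only in the configuration as drawn), and it concerns configuration alone. Compound 3 `Cc1cc(Cl)ccc1NC(=O)[C@H](N)C(C)C` differs from compound 2 by isopropyl in place of methyl on a saturated chain carbon bound to an amine nitrogen and a carbonyl carbon. Among the measured compounds shown here, no measured step touches a change of this kind, so the pair of compound 1 and compound 2 offers no guidance on whether a larger group on that carbon moves the number up or down. With nothing pointing one way or the other, compound 3 is expected to shift only by a 1.1-fold higher number from compound 2 to compound 3 (0.06 log units; within the scatter), a step that may well stay within the scatter. Compound 3 is therefore estimated at 45 mg/kg, with a range from 20 mg/kg to 100 mg/kg to reflect the absence of any bearing step.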

Compound 3, dose for half-maximal effect: 19.6 mg/kg
Beside the measured number, compound 3's estimate is 2.3-fold (0.36 log units) above it; measured number outside the range, below it.
By their numbers in this assay, from the lowest: compounds 3, 2 and 1 (each within the scatter of the next, the first and the last beyond it).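

In this assay the first change other than configuration, isopropyl in place of methyl on a saturated chain carbon bound to an amine nitrogen and a carbonyl carbon, gives a 2.0-fold lower number from compound 2 to compound 3 (0.30 log units; within the scatter) and thus no separable change from compound 2. The comparison with the other drawn configuration gives a 2.1-fold lower number from compound 1 to compound 3 (0.32 log units; beyond the scatter) as a modest step, so this position accepts the larger group with no rise in the number. Nothing on hand gives a reason for these steps.

Going by these compounds, whether a longer chain or a phenyl group on that carbon would move the number further remains open. Also open, on these data alone, is how the mirror-image form of compound 3 would compare, and so whether configuration matters any more with isopropyl than it does with methyl.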